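Amide Variation on a Quinolinone Adenosine A2b Antagonist Series

The source may report more compounds than this note shows. Statements on the series, on what has been measured and on what is new or still open speak of the compounds shown alone.

Measured compounds:
compound 1 `CS(=O)(=O)c1c(CCc2ccccc2)c2cc(OCC(=O)Nc3ccccc3)ccc2[nH]c1=O` — 1680 nM
compound 2 `Cn1c(=O)c(S(C)(=O)=O)c(CCc2ccccc2)c2cc(OCC(=O)NCc3ccc(Cl)c(Cl)c3)ccc21` — > 5000 nM

Among the measured compounds shown here, in a functional assay on CHO cells for antagonist activity at adenosine receptor A2b (Homo sapiens), read by cAMP accumulation, with stated times of 15 min and 1 h (on this read-out lower numbers stand for stronger inhibition and higher numbers for weaker inhibition), compound 1 gives 1680 nM, the only number among the values shown. Compound 2 returns a limit of the assay, > 5000 nM, as noted in the limit of > 5000 nM in this assay, at which 1 of the 2 values shown sits. Compound 3 `CN(Cc1ccc(Cl)c(Cl)c1)C(=O)COc1ccc2[nH]c(=O)c(S(C)(=O)=O)c(CCc3ccccc3)c2c1` has not been measured; it differs from compound 1 in one place: (3,4-dichlorobenzyl)(methyl)amino in place of anilino on a carbonyl carbon. For the measured compounds named here, no measured step covers this change, so the expectation rests on compound 1 alone. Compound 3 is expected to be weaker, with an estimated 2.4-fold higher number from compound 1 to compound 3 (0.38 log units; beyond the scatter), giving 4000 nM with a range from 1500 nM to 12000 nM.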

Compound 3, inhibition constant: 1020 nM
The estimate for compound 3 lay 3.9-fold (0.59 log units) above the measured number; measured number outside the range, below it.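

In this assay the exchange at this carbonyl carbon gives a 1.6-fold lower number from compound 1 to compound 3 (0.22 log units; within the scatter), so (3,4-dichlorobenzyl)(methyl)amino and anilino cannot be told apart here. The place therefore tolerates a group that has no hydrogen-bond donor and carries the dichlorobenzyl ring, with activity staying in the range of compound 1. Nothing measured here explains this result. As far as these compounds go, it remains open whether a smaller amine such as dimethylamino, or a morpholine, would read the same at this carbonyl carbon.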